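The source may report more compounds than this note shows. Statements on the series, on what has been measured and on what is new or still open speak of the compounds shown alone.

Compound 1: `Cc1nn(-c2ncnc3nc[nH]c23)c2c1C(OCC(=O)c1ccc(F)cc1)CC(=O)N2`, 973 nM
Compound 2: `Cc1nn(-c2ncnc3nc[nH]c23)c2c1C(C(=O)N(C)c1nccs1)CC(=O)N2`, 3300 nM

Of the compounds shown here, two sharing one core have been tested in a functional assay on HEK293 cells for agonist activity at G-protein coupled receptor 39 (Homo sapiens), read by scintillation proximity assay and inositol phosphate accumulation, with a stated time of 75 min; on this read-out higher numbers stand for an effect only at larger amounts of compound and lower numbers for an effect already at smaller amounts. Compound 2 gives the higher of the two numbers; its gap to compound 1 lies beyond the usual scatter. Compound 3, `Cc1nn(-c2ncnc3nc[nH]c23)c2c1C(OCCc1ccccc1)CC(=O)N2`, remains unmeasured. It differs from compound 2 in one place: phenethyloxy in place of methyl(1,3-thiazol-2-yl)carbamoyl on a saturated ring carbon. That replacement brings compound 3 closer in build to compound 1, whose oxygen-linked side chain also ends in a six-membered aromatic ring. The step from compound 2 to compound 3 in this assay is therefore expected to be a 2.8-fold lower number from compound 2 to compound 3 (0.44 log units; beyond the scatter), toward a smaller number. Compound 3 is estimated at 1200 nM, within 400 nM to 4000 nM.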

Compound 3, half-maximal effective concentration: 40 nM
Compound 3: the middle estimate sits 30-fold (1.48 log units) above what was measured; measured number outside the range, below it.
By their numbers in this assay, from the lowest: compound 3; then compound 1; then compound 2.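

On the saturated ring carbon, the choice of side chain matters greatly in this assay: phenethyloxy in place of methyl(1,3-thiazol-2-yl)carbamoyl gives an 83-fold lower number from compound 2 to compound 3 (1.92 log units; beyond the scatter), though both groups have 9 heavy atoms. The make-up of the oxygen-linked chain matters too: benzyl in place of (4-fluorophenyl)carbonyl gives a 24-fold lower number from compound 1 to compound 3 (1.39 log units; beyond the scatter), so an oxygen link and a terminal six-membered aromatic ring do not alone set the number. No measurement here explains either step. Still open, going by these compounds, is how a longer phenylpropoxy chain would read out on this carbon. On these data alone, an amine at the same place is equally open.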